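Swapping one five-membered ring for another at compound 4

The source may report more compounds than this note shows. Statements on the series, on what has been measured and on what is new or still open speak of the compounds shown alone.

Measured in a physicochemical assay for lipophilicity, measured as octanol-water partition, at pH 7.4; a higher number here means a more lipophilic compound, a lower number a more polar compound:
compound 1 `O=C([C@H](O)CS(=O)(=O)c1ccc2cc(Cl)ccc2c1)N1CCC(N2Cc3cccn3C2=O)CC1`: 2.6
compound 2 `O=C([C@H](O)CS(=O)(=O)c1ccc2cc(Cl)ccc2c1)N1CCC(N2CCNC2=O)CC1`: 1.73
compound 3 `O=C([C@H](O)CS(=O)(=O)c1ccc2cc(Cl)ccc2c1)N1CCC(N2CCOC2=O)CC1`: 1.75

Compound 3, at 1.75, sits level with compound 2: the gap to this nearest neighbour is a number 0.02 log units higher from compound 2 to compound 3 (within the scatter). Compound 1 lies clearly higher, and the gap to it is a number 0.85 log units lower from compound 1 to compound 3 (beyond the scatter).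

Compound 4 `O=C([C@H](O)CS(=O)(=O)c1ccc2cc(Cl)ccc2c1)N1CCC(N2CCCC2=O)CC1` has not been measured yet. It differs from compound 3 in one place, with 2-oxopyrrolidin-1-yl in place of 2-oxo-1,3-oxazolidin-3-yl on a saturated ring carbon.

Two kinds of measured step could guide an expectation. The large ones, a number 0.87 log units lower from compound 1 to compound 2 (beyond the scatter) and a number 0.85 log units lower from compound 1 to compound 3 (beyond the scatter), both lose a five-membered aromatic ring, and compound 4 involves no such loss. The closer parallel is a number 0.02 log units higher from compound 2 to compound 3 (within the scatter), a swap between two five-membered non-aromatic rings of the same heavy-atom count. That is a single example, so the guidance is thin, but it points to a small change. In this assay the expected step is a number 0.15 log units higher from compound 3 to compound 4 (within the scatter), so no shift beyond the scatter is expected.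

For compound 4 the estimated value is 1.9, with an expected range from 1.5 to 2.3.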

Compound 4, distribution coefficient: 1.96
The estimate for compound 4 lay 0.06 log units below the measured number; the range from low to high includes it.
By their numbers in this assay, from the lowest: compounds 2, 3 and 4 (each within the scatter of the next); then compound 1.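

With 2-oxopyrrolidin-1-yl on the saturated ring carbon, this assay gives a number 0.21 log units higher from compound 3 to compound 4 (within the scatter) and a number 0.23 log units higher from compound 2 to compound 4 (within the scatter), so a five-membered non-aromatic ring with 1 hetero atom stands level with both rings that have 2 hetero atoms. Until now only two such rings could be compared, and this third ring shows that, among these three, the identity of the second hetero atom, or a carbon in its place, produces no step beyond the scatter at this position. The group carrying the additional five-membered aromatic ring still stands apart, at a number 0.64 log units lower from compound 1 to compound 4 (beyond the scatter), and no supporting measurement is available to explain any of these results.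

All the groups shown at this position are five-membered rings bearing an oxo group, so it remains open what a six-membered piperidin-2-one ring, an open-chain amide, or a ring carrying an amine or a carboxylic acid would give. Whether such a group would stay level with compound 2, compound 3 and compound 4, or move beyond the scatter as the group in compound 1 does, cannot be told from these values.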